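The source may hold more compounds than are shown below. What is called first, only, known or untested is meant among the compounds shown, and "the series" means these compounds.

Measured compounds and their values:

Compound 1, `COc1ccc(N/C=C\C(=O)c2nc(-c3ccc(F)cc3)n3ccccc23)cc1`: 19200 nM
Compound 2, `COc1ccc(N/C=C\C(=O)c2nc(-c3ccc(OC)cc3)n3ccccc23)cc1`: "not determined" (no result reported)
Compound 3, `COc1ccc(N/C=C\C(=O)c2nc(-c3ccc(F)cc3)n3ccccc23)cc1OC`: > 30000 nM

In a functional assay on A549 cells (Homo sapiens) for cytotoxicity, read by MTT assay, with a stated time of 48 h (on this read-out higher numbers stand for weaker inhibition and lower numbers for stronger inhibition), compound 1 gives 19200 nM. Compound 3 gives only > 30000 nM in this assay, which is a limit of the assay and not a number; the limit of > 30000 nM in this assay, at which 1 of the 3 values shown sits, describes it. For compound 2 no number is reported in this assay.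

Compound 3 and compound 1 differ by a single change, (hydrogen in place of methoxy on an aromatic carbon). That change produced an at least 1.5-fold lower number from compound 3 to compound 1 (0.19 log units; that floor lies within the scatter), a step whose floor lies within the usual scatter, so the two compounds may simply be close to each other.

Compound 2 and compound 3 differ in more than one place, and the difference between the two cores is not broken down here.

Compound 4, `COc1ccc(N/C=C\C(=O)c2nc(-c3ccccc3)n3ccccc23)cc1`, is not yet measured. It differs from compound 2 by hydrogen in place of methoxy on an aromatic carbon. This is the same kind of change as from compound 3 to compound 1, but the surroundings differ: in the measured pair the leaving methoxy sat ortho to a methoxy group and meta to a large group, whereas in compound 2 it sits para to a large group. Since compound 2 has no number, the expectation for compound 4 rests on the small size of an at least 1.5-fold lower number from compound 3 to compound 1 (0.19 log units; that floor lies within the scatter) and on the value of compound 1, 19200 nM, which shares most of its structure with compound 4. The expected value for compound 4 in this assay is 25000 nM, with a likely range from 10000 nM to 60000 nM.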

Compound 4, half-maximal inhibitory concentration: > 30000 nM
Compound 4 was reported as a limit; the forecaster's own chance of this, stated with the estimate: 40%; at least 1.2-fold (0.07 log units) between middle value and limit.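

Compound 4 is reported only as a limit of the assay, not as a number: the limit of > 30000 nM in this assay, at which 2 of the 4 values shown sit. Among the compounds shown here, putting hydrogen in place of fluoro gives an at least 1.5-fold higher number from compound 1 to compound 4 (0.19 log units; that floor lies within the scatter), so this shows only that compound 1 and compound 4 may simply lie close together, and it does not show that the fluoro group matters for the cytotoxic effect. For the compounds shown here, compound 2 has no number, so the step from it to compound 4, 4-methoxyphenyl to phenyl, cannot be read; an at least 1.5-fold lower number from compound 3 to compound 1 (0.19 log units; that floor lies within the scatter) is therefore the only reading of methoxy giving way to hydrogen, and whether that result carries from one core to another remains untested.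

The compounds shown leave open how the number would respond if an amine or a carboxylic acid stood in place of the fluoro group, on the same aromatic carbon para to a large group. They also leave open whether any group at that place can move the number clearly away from that of compound 1, which gives 19200 nM in this assay. Values sitting at the limit cannot settle this question.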